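Alkyl groups on the ring nitrogen of the shared core

This account rests on a few compounds, and the source may have more. Where it says the series, first, only, none or still open, it means among the compounds named here.

Of the compounds shown here, three on a shared core have been measured in an assay on V79 cells for inhibition of cytochrome P450 11B1, mitochondrial (Homo sapiens), read by HTRF, with a stated time of 1 h; on this read-out lower numbers stand for stronger inhibition and higher numbers for weaker inhibition. Compound 1 `Cn1c(-c2cccnc2)nc2ccc(F)cc21` carries a methyl on the aromatic nitrogen and gives 677 nM. Compound 2 `Fc1ccc2nc(-c3cccnc3)n(C3CC3)c2c1` carries a cyclopropyl at that place and gives 401 nM. Compound 3 `Fc1ccc2nc(-c3cccnc3)[nH]c2c1` carries hydrogen there and gives 1990 nM, the highest of the three numbers; its nearest number is that of compound 1 and its furthest that of compound 2. Among the measured steps, a 1.7-fold lower number from compound 1 to compound 2 (0.23 log units; within the scatter), whereas a 2.9-fold higher number from compound 1 to compound 3 (0.47 log units; beyond the scatter) and a 5.0-fold higher number from compound 2 to compound 3 (0.70 log units; beyond the scatter).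

Compound 4 `CCn1c(-c2cccnc2)nc2ccc(F)cc21` differs from compound 3 by ethyl in place of hydrogen on an aromatic nitrogen. The two steps that bear on this change are those that exchange an alkyl group on the aromatic nitrogen for hydrogen, from compound 1 to compound 3 and from compound 2 to compound 3; both were modest and beyond the scatter, and the step to compound 4 runs the opposite way, restoring an alkyl group. A modest step to a lower number in this assay is therefore expected for compound 4, with ethyl expected to land between methyl and cyclopropyl in this respect. The estimate for compound 4 is 500 nM with a range of 250 nM to 1000 nM. For compound 4 that estimate amounts to an expected step of a 4.0-fold lower number from compound 3 to compound 4 (0.60 log units; beyond the scatter).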

Compound 4, half-maximal inhibitory concentration: 2100 nM
For compound 4 the middle estimate is 4.2-fold (0.62 log units) below the measured one; the whole stated range lies below it.
By their numbers in this assay, from the lowest: compounds 2 and 1 (each within the scatter of the next); then compounds 3 and 4 (each within the scatter of the next).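

Working notes on the aromatic nitrogen: in this assay, the presence of an alkyl group at this position does not by itself separate a compound from the hydrogen compound, since ethyl in place of hydrogen gives a 1.1-fold higher number from compound 3 to compound 4 (0.02 log units; within the scatter) and so stays within the scatter. The earlier picture, in which methyl and cyclopropyl both gave lower numbers than hydrogen, therefore holds only for those two groups, and compound 4 goes against it. The ethyl compound stands apart from both of them, with a 3.1-fold higher number from compound 1 to compound 4 (0.49 log units; beyond the scatter) for the one added carbon on the chain and a 5.2-fold higher number from compound 2 to compound 4 (0.72 log units; beyond the scatter) for the exchange of cyclopropyl for ethyl, so the read-out here depends on which alkyl group is present; no supporting data are at hand to explain this difference among the alkyl groups.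

Going by these compounds, whether a longer chain such as propyl or a branched group such as isopropyl would read like ethyl or like methyl and cyclopropyl remains open. Also open, on these data alone, is how a larger ring such as cyclobutyl, or a chain ending in an amine or a carboxylic acid, would read at this nitrogen.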